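Methoxy for trifluoromethyl and Vero cell cytotoxicity

The source may report more compounds than this note shows. Statements on the series, on what has been measured and on what is new or still open speak of the compounds shown alone.

Measured so far in an ADME assay on Vero cells (Chlorocebus sabaeus) for cytotoxicity, read by MTT assay, with a stated time of 96 h; on this read-out higher numbers stand for lower toxicity in this test and lower numbers for higher toxicity in this test:
compound 1, `C/C(=N\NC(N)=S)c1ccc2[nH]c(-c3ccc(C(F)(F)F)cc3)nc2c1`, gives 22000 nM.
compound 2, `COc1ccc(-c2nc3cc(/C(C)=N/NC(N)=S)ccc3[nH]2)cc1`, gives only a limit of the assay, > 100000 nM.
compound 3, `CC(=O)c1ccc2c(c1)nc(-c1ccc(C(F)(F)F)cc1)n2C1CCCCC1`, gives 35000 nM.

Among the compounds with values here, the one single-point step measured is methoxy in place of trifluoromethyl on an aromatic carbon. It gave an at least 4.5-fold higher number from compound 1 to compound 2 (0.65 log units; beyond the scatter), and because of the limit of > 100000 nM in this assay, at which 1 of the 3 values shown sits, its full size is not known, only its floor.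

Compound 3 carries a different core; the difference between the two cores is not broken down here. In this assay compound 3 and compound 1 lie within the scatter of each other.

Compound 4, `COc1ccc(-c2nc3cc(C(C)=O)ccc3n2C2CCCCC2)cc1`, is not yet measured. It differs from compound 3 by methoxy in place of trifluoromethyl on an aromatic carbon, the same change as from compound 1 to compound 2. On the strength of an at least 4.5-fold higher number from compound 1 to compound 2 (0.65 log units; beyond the scatter), a rise of at least that size is expected, which would be a 3.4-fold higher number from compound 3 to compound 4 (0.54 log units; beyond the scatter) from compound 3 to compound 4 in this assay. For compound 4 the expected value is therefore 120000 nM, between 45000 nM and 350000 nM, with a fair chance that only a limit is reported.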

Compound 4, half-maximal cytotoxic concentration: 30000 nM
Beside the measured number, compound 4's estimate is 4.0-fold (0.60 log units) above it; the measured number lies below the stated range.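

In this assay, methoxy in place of trifluoromethyl gave a 1.2-fold lower number from compound 3 to compound 4 (0.07 log units; within the scatter), so the change did not carry over from the core of compound 1 to the core of compound 3, and the two steps differ: the same change on two cores in this assay, an at least 4.5-fold higher number (0.65 log units; beyond the scatter) from compound 1 to compound 2 and a 1.2-fold lower number (0.07 log units; within the scatter) from compound 3 to compound 4, at least 5.3-fold (0.72 log units) apart, beyond the scatter of two such steps

Compound 2 stands at a limit of the assay, so the step leading to it has a floor but no known full size: the limit of > 100000 nM in this assay, at which 1 of the 4 values shown sits.

Within the data shown here, the comparison shows that this step depends on the core, but it rests on only two pairs and does not show which part of the difference between the two cores is responsible, nor does it give a rule for other cores.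

Which structural difference between the cores decides the outcome remains open. Also open, as far as these compounds go, is whether a nitrile, an amine or a carboxylic acid in place of trifluoromethyl would likewise give different steps on the two cores.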